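Working notes: three measured antagonists and one untested analogue

The compounds below may be only part of what the source reports. "The series", "measured", "known", "first", "only" and "open" are said of these compounds alone.

Measured compounds, all in an in vitro functional assay on HEK285-7 cells for antagonist activity at prostaglandin D2 receptor 2 (Homo sapiens), read by BRET and beta-arrestin recruitment; a lower number here means a stronger inhibitor, a higher number a weaker inhibitor:
- compound 1, `O=C(O)Cc1sc(C(c2ccccc2)c2ccc(Cl)cc2)nc1-c1ccc(Cl)cc1`, gives 75 nM
- compound 2, `COc1ccc(C(c2ccccc2)c2nc(-c3ccc(Cl)cc3)c(CC(=O)O)s2)cc1`, gives 76 nM
- compound 3, `O=C(O)Cc1sc(C(c2ccccc2)c2ccccn2)nc1-c1ccc(Cl)cc1`, gives 1900 nM

Compound 3 has the highest number of the three. The two others sit close together, compound 1 and compound 2 differing only by a 1.0-fold higher number from compound 1 to compound 2 (0.01 log units; within the scatter), while compound 3 lies well apart from both: a 25-fold higher number from compound 1 to compound 3 (1.40 log units; beyond the scatter) and a 25-fold higher number from compound 2 to compound 3 (1.40 log units; beyond the scatter).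

The next analogue, compound 4, `O=C(O)Cc1sc(C(Cc2ccccc2)c2ccccc2)nc1-c1ccc(Cl)cc1`, has not yet been measured in this assay. It differs from compound 3 as follows: benzyl in place of pyridin-2-yl on a saturated chain carbon bound to two aromatic carbons.

For the measured compounds named here, two measured steps bear on this. In both, a carbon-only aromatic ring at the saturated chain carbon bound to two aromatic carbons was exchanged for pyridin-2-yl, and both gave a large loss: a 25-fold higher number from compound 1 to compound 3 (1.40 log units; beyond the scatter); a 25-fold higher number from compound 2 to compound 3 (1.40 log units; beyond the scatter). Compound 4 goes the other way, back to a carbon-only ring with no hydrogen-bond acceptor, though as benzyl rather than the aryl groups of compound 1 and compound 2, so the reverse step is not tested directly. A sizeable gain beyond the scatter is therefore expected in this assay, though likely not a full return to the level of compound 1.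

For compound 4 the expected value is 250 nM, with a range from 80 nM to 900 nM. That corresponds to an expected step of a 7.6-fold lower number from compound 3 to compound 4 (0.88 log units; beyond the scatter).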

Compound 4, half-maximal inhibitory concentration: 510 nM
The estimate for compound 4 lay 2.0-fold (0.31 log units) below the measured number; the measured number falls inside the stated range.
By their numbers in this assay, from the lowest: compounds 1 and 2 (each within the scatter of the next); then compound 4; then compound 3.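

In this assay, the exchange of pyridin-2-yl for benzyl at the saturated chain carbon bound to two aromatic carbons gives back only part of the ground separating compound 3 from the two aryl compounds (a 3.7-fold lower number from compound 3 to compound 4 (0.57 log units; beyond the scatter)). Compound 4 stays clearly apart from both of them (a 6.7-fold higher number from compound 2 to compound 4 (0.83 log units; beyond the scatter); a 6.8-fold higher number from compound 1 to compound 4 (0.83 log units; beyond the scatter)), so removing the ring nitrogen and its hydrogen-bond acceptor does not, in this benzyl form, reach the level of compound 1 and compound 2, and this position now shows three distinct levels rather than two. No supporting data are available to explain why benzyl falls short of the 4-chlorophenyl and 4-methoxyphenyl groups or ranks ahead of pyridin-2-yl.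

Still open, from the compounds shown here alone, is whether the shortfall of compound 4 belongs to the added methylene link or to the missing ring substituent, which 4-chlorobenzyl and an unsubstituted phenyl at this carbon would help separate. Also open, going by these compounds, is whether pyridin-3-yl or pyridin-4-yl carries the same penalty as pyridin-2-yl, and whether a longer chain such as 2-phenylethyl continues the trend seen with benzyl.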